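A few compounds are considered here, and "the series" means these few. Any claim that something is new, unique, unknown or untested is made for them only; others in the source may bear on it.

Measured in a functional assay on HT cells (Homo sapiens) for antiproliferative activity, read by fluorescence, with a stated time of 72 h; a higher number here means a weaker inhibitor of growth, a lower number a stronger inhibitor of growth:
compound 1 `CC(C)c1n[nH]c2c(NCc3ccc(-c4ccccn4)cc3)nc(SCC(N)=O)nc12` gives 192 nM
compound 2 `CC(C)c1n[nH]c2c(NCc3ccc(-c4ccccn4)cc3)nc(SC[C@H](O)CN)nc12` gives 63 nM
compound 3 `CC(C)c1n[nH]c2c(NCc3ccc(-c4ccccn4)cc3)nc(SCCn3ccnc3)nc12` gives 155 nM

Compound 3 stands second highest of the three numbers; its nearest neighbour is compound 1, a 1.2-fold lower number from compound 1 to compound 3 (0.09 log units; within the scatter), and compound 2 lies furthest, a 2.5-fold higher number from compound 2 to compound 3 (0.39 log units; beyond the scatter).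

Compound 4 `CC(C)c1n[nH]c2c(NCc3ccc(-c4ccccn4)cc3)nc(SC3CCCC3O)nc12` is not yet measured. The change from compound 3: 2-hydroxycyclopentyl in place of 2-(1H-imidazol-1-yl)ethyl on a sulfur. All three measured steps alter the group on the same sulfur: a 3.0-fold lower number from compound 1 to compound 2 (0.48 log units; beyond the scatter), a 1.2-fold lower number from compound 1 to compound 3 (0.09 log units; within the scatter), a 2.5-fold higher number from compound 2 to compound 3 (0.39 log units; beyond the scatter). Only compound 2, with 2-amino-1-hydroxyethyl, gives the lowest number, 63 nM. For compound 4 a modest fall in this assay is expected, a 1.3-fold lower number from compound 3 to compound 4 (0.11 log units; within the scatter), kept small because a 2.5-fold higher number from compound 2 to compound 3 (0.39 log units; beyond the scatter) was itself modest. Compound 4 is estimated at 120 nM, range 50 nM to 300 nM.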

Compound 4, concentration for 50% growth inhibition: 567 nM
Compound 4: the middle estimate sits 4.7-fold (0.67 log units) below what was measured; the measured number lies above the stated range.
By their numbers in this assay, from the lowest: compound 2; then compounds 3 and 1 (each within the scatter of the next); then compound 4.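

In this assay, compound 4 is the weakest of the four, and the group on the sulfur now changes the number upward against every earlier compound (a 3.7-fold higher number from compound 3 to compound 4 (0.56 log units; beyond the scatter); a 3.0-fold higher number from compound 1 to compound 4 (0.47 log units; beyond the scatter); a 9.0-fold higher number from compound 2 to compound 4 (0.95 log units; beyond the scatter)). The largest step is from 3-amino-2-hydroxypropyl, so a hydroxyl on the group, as carried by 2-hydroxycyclopentyl, does not alone match compound 2. No supporting data bear on this loss.

Open, from the compounds shown here alone, is whether an amine on the cyclopentyl ring would bring the number back toward that of compound 2. Also open, going by these compounds, is whether a simple open-chain hydroxyethyl group would behave like compound 2 or compound 4.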